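This account rests on a few compounds, and the source may have more. Where it says the series, first, only, none or still open, it means among the compounds named here.

Measured in a functional assay on DU-145 cells (Homo sapiens) for cytotoxicity; a lower number here means a stronger inhibitor of growth, a higher number a weaker inhibitor of growth:
- compound 1 `CSc1ccc(C2=C(c3ccc(F)c(F)c3)C(=O)N3CCCC3C2)cc1`: 500 nM
- compound 2 `CSc1ccc(C2=C(c3ccc(Br)cc3)C(=O)N3CCCC3C2)cc1`: 9000 nM

Of these two compounds, compound 2 has the higher number, at 9000 nM, so it is the weaker inhibitor of growth in this assay. The next compound to be tested is compound 3 `CSc1ccc(C2=C(c3ccc(SC)cc3)C(=O)N3CCCC3C2)cc1`, which has methylsulfanyl in place of bromo on an aromatic carbon. Among the compounds with values here, the only measured step, an 18-fold higher number from compound 1 to compound 2 (1.26 log units; beyond the scatter), involved the same aryl group but a different exchange. It shows that changes to this group can move the number a long way, but no measurement covers this particular swap. A moderate move towards a lower number therefore seems more likely than a further rise, with considerable uncertainty. The estimated change is a 2.3-fold lower number from compound 2 to compound 3 (0.35 log units; beyond the scatter). For compound 3 the expected value is 4000 nM, with an estimated range of 800 nM to 15000 nM.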

Compound 3, concentration for 50% growth inhibition: 8000 nM
Beside the measured number, compound 3's estimate is 2.0-fold (0.30 log units) below it; measured number inside the range.
By their numbers in this assay, from the lowest: compound 1; then compounds 3 and 2 (each within the scatter of the next).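

In this assay, the exchange at this aromatic carbon, para to a large group, gives a 1.1-fold lower number from compound 2 to compound 3 (0.05 log units; within the scatter), so methylsulfanyl and bromo cannot be told apart here, although methylsulfanyl brings two heavy atoms and a hydrogen-bond acceptor where bromo has one heavy atom and none. Exchanging 3,4-difluorophenyl for 4-(methylsulfanyl)phenyl gives a 16-fold higher number from compound 1 to compound 3 (1.20 log units; beyond the scatter), so the large step seen with 4-bromophenyl is not confined to bromo. Nothing available explains why these two groups give such similar numbers.

The compounds shown leave open whether compound 1 owes its lower number to both fluorines or whether a single fluoro on that aryl group would serve as well. They also leave open how an amine or a carboxylic acid at this position would read in this assay.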